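A difluorobenzyl amide in a series without readable values

The source may hold more compounds than are shown below. What is called first, only, known or untested is meant among the compounds shown, and "the series" means these compounds.

compound 1 `COc1ccc2c(=O)c(/C=C/C(=O)Nc3ccccc3Cl)coc2c1` gives > 200000 nM
compound 2 `COc1ccc2c(=O)c(/C=C/C(=O)NCc3cccc(F)c3)coc2c1` gives > 200000 nM
compound 3 `COc1ccc2c(=O)c(/C=C/C(=O)Nc3ccc(F)cc3)coc2c1` gives > 200000 nM

All three results come from a functional assay on L02 cells (Homo sapiens) for inhibition, read by MTT assay, with a stated time of 48 h (a higher number here means a weaker inhibitor, a lower number a stronger inhibitor), and none is a number. In this assay compound 3 gives > 200000 nM as a limit of the assay. Going by the values given here, it has no better-defined neighbour to be placed against, as the series so far shows the limit of > 200000 nM in this assay, at which 3 of the 3 values shown sit, and nothing else.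

Compound 4 `COc1ccc2c(=O)c(/C=C/C(=O)NCc3ccc(F)cc3F)coc2c1` changes the group on the amide-type nitrogen, with 2,4-difluorobenzyl in place of 4-fluorophenyl on an amide-type nitrogen as the only difference. Among the compounds with values here, three measured steps bear on this change: a step that the two limits leave unreadable from compound 2 to compound 3 and a step that the two limits leave unreadable from compound 1 to compound 2 and a step that the two limits leave unreadable from compound 1 to compound 3 all exchange the group at the same nitrogen. None of them has a readable size or direction, so they support no expected shift. Compound 2, the only measured benzyl amide, gives > 200000 nM as a limit too.

No step beyond the scatter is therefore expected in this assay, and a further limit is the likeliest report. The estimated change is a step that the limit leaves unreadable from compound 3 to compound 4 and should be read with that in mind. For compound 4 the estimated value is 250000 nM and the expected range runs from 120000 nM to 400000 nM as a working figure.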

Compound 4, half-maximal inhibitory concentration: > 200000 nM
Compound 4: only a limit was reported (the forecaster's own chance of this, stated with the estimate: 85%); the middle value is on the limit's open side.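

In this assay compound 4 gives > 200000 nM, a limit of the assay and not a number. No step linking compound 4 with compound 1, compound 2 or compound 3 can be read, because all four share one limit: the limit of > 200000 nM in this assay, at which 4 of the 4 values shown sit.

Left open is how these four groups on the amide-type nitrogen rank in this assay, and whether any group there gives a readable value.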